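Flipping the exocyclic double bond of compound 2

A few compounds are considered here, and "the series" means these few. Any claim that something is new, unique, unknown or untested is made for them only; others in the source may bear on it.

Measured so far:
- compound 1, `O=Cc1cccc(OCc2cn(Cc3ccccc3)nn2)c1`: > 50000 nM
- compound 2, `COc1cc(Cn2cc(COc3cccc(/C=C4\C(=O)Nc5ccccc54)c3)nn2)cc(OC)c1`: 31700 nM

The two compounds measured in a functional assay on PC-3 cells (Homo sapiens) for inhibition, read by MTT assay, with a stated time of 48 h (a higher number here means a weaker inhibitor, a lower number a stronger inhibitor), give very different pictures. Compound 1 reaches only the limit of the assay, > 50000 nM, so no number is known for it; this is the case described by the limit of > 50000 nM in this assay, at which 1 of the 2 values shown sits. Within the data shown here, compound 2 is the only compound with a measured number, and that number, 31700 nM, marks it as a weak inhibitor in this assay.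

Compound 3, `COc1cc(Cn2cc(COc3cccc(/C=C4/C(=O)Nc5ccccc54)c3)nn2)cc(OC)c1`, keeps every atom and bond of compound 2. The difference is the two compounds have the same atoms and bonds and differ only in configuration as drawn: 1 of 1 stereo elements differ; a double bond is drawn Z in compound 2 and E in compound 3. Among the measured compounds shown here, no pair of measured compounds shows what such a change does here, so there is nothing to lean on beyond the weak number of compound 2 itself.

The change is expected to be modest, likely no larger than the usual scatter, with no clear direction: the step from compound 2 to compound 3 is estimated at a 1.1-fold lower number from compound 2 to compound 3 (0.02 log units; within the scatter). Compound 3 is therefore expected to sit near 30000 nM, with a plausible range from 10000 nM to 80000 nM.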

Compound 3, half-maximal inhibitory concentration: 37100 nM
Beside the measured number, compound 3's estimate is 1.2-fold (0.09 log units) below it; measured number inside the range.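

In this assay, reversing the exocyclic double bond gives a 1.2-fold higher number from compound 2 to compound 3 (0.07 log units; within the scatter), so this read-out does not tell the two drawn forms apart. This is the first pair shown that isolates a single change, which makes it a clean test of this double bond, and nothing else varies within it: the fact that compounds 2 and 3 differ only in the configuration as drawn The configuration of this double bond therefore makes no difference that can be read in this assay, and compound 2 and compound 3 are both weak inhibitors, so neither drawn form offers a better starting point than the other.

The compounds shown leave open whether a different group on the shared core, such as an amine or a carboxylic acid, would move the number beyond the scatter. Compound 1 gives > 50000 nM, which is a limit of the assay and not a number, and it differs from compound 2 in more than one place, so it cannot settle what any single part of the structure contributes.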